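The compounds below may be only part of what the source reports. "The series", "measured", "known", "first", "only" and "open" are said of these compounds alone.

Going by the values given here, compound 2 `O=C1/C(=C\c2ccccc2Cl)c2ccccc2N1c1c(Cl)cccc1Cl` gives 9 ug/mL in a functional assay on MCF7 cells (Homo sapiens) for cytotoxicity, read by MTT assay, with a stated time of 72 h (on this read-out higher numbers stand for an effect only at larger amounts of compound and lower numbers for an effect already at smaller amounts), level with its nearest measured neighbour, compound 1 `O=C1/C(=C\c2ccc(F)cc2)c2ccccc2N1c1c(Cl)cccc1Cl`, which gives 9 ug/mL in this assay; the one step between measured compounds is no change at the digits printed from compound 1 to compound 2 (within the scatter). Compound 3 `O=C1/C(=C\c2ccc(Cl)cc2)c2ccccc2N1c1c(Cl)cccc1Cl` differs from compound 2 by 4-chlorophenyl in place of 2-chlorophenyl on a double-bonded chain carbon bound to a double-bonded ring carbon. That single step also exchanged the phenyl group at this place and moved nothing beyond the scatter, so a step of about no change at the digits printed from compound 2 to compound 3 (within the scatter) is expected, with no direction beyond the scatter. The estimate for compound 3 in this assay is therefore 9 ug/mL, within 3.5 ug/mL to 25 ug/mL.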

Compound 3, concentration for half-maximal effect: 5 ug/mL
The estimate for compound 3 lay 1.8-fold (0.26 log units) above the measured number; measured number inside the range.
By their numbers in this assay, from the lowest: compounds 3, 1 and 2 (each within the scatter of the next).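

In this assay, 4-chlorophenyl in place of 2-chlorophenyl on a double-bonded chain carbon bound to a double-bonded ring carbon gives a 1.8-fold lower number from compound 2 to compound 3 (0.26 log units; within the scatter), and chloro in place of fluoro on an aromatic carbon gives a 1.8-fold lower number from compound 1 to compound 3 (0.26 log units; within the scatter). All three phenyl groups tried at this place therefore stay within the scatter of one another, for a changed halogen as well as for a changed chlorine position. No supporting data bear on this result. The compounds shown leave open whether an amine, a carboxylic acid or a methoxy group on this phenyl would move the number beyond the scatter. They also leave open how any change to the shared core would read.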